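Fluoro for chloro in a series without readable numbers

A few compounds are considered here, and "the series" means these few. Any claim that something is new, unique, unknown or untested is made for them only; others in the source may bear on it.

Compound 1 `O=C(Nc1ccc(Cl)c(-c2nnc3c(Cl)cccn23)c1)c1ccc(C(F)(F)F)cc1Cl` is tested in a functional assay on MDA-MB-468 cells (Homo sapiens) for antiproliferative activity, read by MTT assay, with a stated time of 72 h; on this read-out higher numbers stand for weaker inhibition and lower numbers for stronger inhibition. Compound 1 gives only a limit there, > 100000 nM, not a number. Compound 2 `O=C(Nc1ccc(Cl)c(-c2nnc3c(Cl)cccn23)c1)c1ccc(F)cc1Cl` differs from compound 1 by fluoro in place of trifluoromethyl on an aromatic carbon. Compound 2 also returns a limit, > 100000 nM. Compound 3 `O=C(Nc1ccc(Cl)c(-c2nnc3c(Cl)cccn23)c1)c1cccnc1` carries pyridin-3-yl in place of 2-chloro-4-fluorophenyl on the carbonyl carbon. Compound 3 likewise sits at a limit, > 100000 nM. The two steps among the measured compounds, a step that the two limits leave unreadable from compound 1 to compound 2 and a step that the two limits leave unreadable from compound 2 to compound 3, therefore cannot be sized; all that is seen is the limit of > 100000 nM in this assay, at which 3 of the 3 values shown sit.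

Compound 4 `O=C(Nc1ccc(Cl)c(-c2nnc3c(Cl)cccn23)c1)c1ccc(C(F)(F)F)cc1F` is not yet measured. It differs from compound 1 by fluoro in place of chloro on an aromatic carbon. The change is a halogen exchange on the same ring that the step from compound 1 to compound 2 also altered, and that step was unreadable. Among the compounds with values here, no measured step bears on it with a readable size, so no direction can be drawn; the three limits give the only guide. Compound 4 is therefore expected to return a limit as well, with a step estimated as a step that the limit leaves unreadable from compound 1 to compound 4. The estimate for compound 4 is 150000 nM, within 50000 nM to 500000 nM.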

Compound 4, half-maximal inhibitory concentration: 22300 nM
Compound 4: middle estimate off by 6.7-fold (0.83 log units), on the high side; measured number outside the range, below it.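

In this assay, within the data shown here, fluoro in place of chloro on the aromatic carbon ortho to a large group and meta to a trifluoromethyl group gives an at least 4.4-fold lower number from compound 1 to compound 4 (0.65 log units; beyond the scatter), the first readable number. Unlike the two earlier steps, which cannot be read, this step shows that the position responds to the exchange of one halogen atom for another, with the trifluoromethyl group and the core of compound 1 kept in place. The step has only a lower bound, and its full size stays unknown, with the rest of the series still at the assay limit: the limit of > 100000 nM in this assay, at which 3 of the 4 values shown sit.

The compounds shown do not separate a gain from fluoro itself from a loss of chloro, and a hydrogen, a methyl or a methoxy group on this same aromatic carbon would be needed to tell the two apart. Also open, from the compounds shown here alone, is whether the same exchange gives a readable number when fluoro or another group, such as a nitrile, stands in place of the trifluoromethyl group.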